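Aryl variation on the saturated ring carbon

A few compounds are considered here, and "the series" means these few. Any claim that something is new, unique, unknown or untested is made for them only; others in the source may bear on it.

Compound 1 `CC(C)[C@H](NC(=O)CCN(C)C)c1cccc(F)c1N1CCN(C(=O)[C@@H]2CN(C(C)C)C[C@H]2c2ccc(Cl)cc2)CC1` gives 20 nM in a functional assay on CHO cells for agonist activity at Melanocortin receptor 4 (Homo sapiens), read by cAMP accumulation; a lower number here means that less compound is needed, a higher number that more compound is needed for the effect. Going by the values given here, compound 2 `CC(C)[C@H](NC(=O)CCN(C)C)c1cccc(F)c1N1CCN(C(=O)[C@@H]2CN(C(C)C)C[C@H]2c2ccc(F)c(Cl)c2)CC1` gives 410 nM in this assay, the highest of the two numbers so far; the one measured step, a 21-fold higher number from compound 1 to compound 2 (1.31 log units; beyond the scatter), is large. Compound 3 `CC(C)[C@H](NC(=O)CCN(C)C)c1cccc(F)c1N1CCN(C(=O)[C@@H]2CN(C(C)C)C[C@H]2c2ccc(C(F)(F)F)c(F)c2)CC1` carries the change (3-fluoro-4-(trifluoromethyl)phenyl in place of 3-chloro-4-fluorophenyl on a saturated ring carbon). Among the compounds with values here, no measured step covers this particular exchange; the step of a 21-fold higher number from compound 1 to compound 2 (1.31 log units; beyond the scatter) shows only that the aryl group on this carbon can move this assay strongly, so a move in either direction remains possible. For compound 3 a step of a 1.0-fold lower number from compound 2 to compound 3 (0.01 log units; within the scatter) is expected, within the scatter. Compound 3 is estimated at 400 nM, range 100 nM to 1600 nM.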

Compound 3, half-maximal effective concentration: 340 nM
The estimate for compound 3 lay 1.2-fold (0.07 log units) above the measured number; low and high end bracket the measured number.
By their numbers in this assay, from the lowest: compound 1; then compounds 3 and 2 (each within the scatter of the next).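

In this assay the exchange of 3-chloro-4-fluorophenyl for 3-fluoro-4-(trifluoromethyl)phenyl gives a 1.2-fold lower number from compound 2 to compound 3 (0.08 log units; within the scatter) and leaves the number in place, even with 11 heavy atoms entering for 8. The gap to 4-chlorophenyl is not particular to compound 2: with a 17-fold higher number from compound 1 to compound 3 (1.23 log units; beyond the scatter) as a second large step, only the aryl group of compound 1 sits at the low end. Nothing available explains why the two disubstituted aryl groups read alike.

Which substituent accounts for the gap stays open, as compound 2 and compound 3 each differ from compound 1 in more than one substituent. From the compounds shown here alone, how a plain phenyl, a methoxyphenyl or a pyridine ring on this carbon would read is also open.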